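The source may hold more compounds than are shown below. What is called first, only, known or untested is meant among the compounds shown, and "the series" means these compounds.

Among the compounds with values here, compound 2, `COc1cc(F)ccc1N1C(=O)CSC1c1cccc(C(=O)NCCCCc2ccccc2)c1`, gives 81% in a functional assay on HOS cells (Homo sapiens) for inhibition, read by CCK-8 assay, with a stated time of 72 h, tested at 1 uM (a higher number here means more inhibition at the concentration tested (going by the name of the read-out), a lower number less inhibition), the lowest of the two numbers known so far; its nearest neighbour is compound 1, `Cc1cccc(N2C(=O)CSC2c2cccc(C(=O)NCCCCc3ccccc3)c2)c1`, which in this assay gives 84%. Within the data shown here, the one measured step, a number 3 percentage points lower from compound 1 to compound 2 (within the scatter), comes from replacing the aryl group on the amide-type nitrogen in the ring, and it stayed within the scatter. Compound 3, `COc1ccc(N2C(=O)CSC2c2cccc(C(=O)NCCCCc3ccccc3)c2)c(OC)c1`, has not yet been measured in this assay. It differs from compound 2 in one place: methoxy in place of fluoro on an aromatic carbon. Among the measured compounds shown here, that step also alters only the aryl group on the ring nitrogen, so the step from compound 1 to compound 2 is the only measured comparison that bears on it, and it was small. Compound 3 is therefore expected to show a step of a number 1 percentage points lower from compound 2 to compound 3 (within the scatter), nothing beyond the scatter. The estimated result for compound 3 in this assay is 80%, with a range from 65% to 92%.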

Compound 3, a percentage reported as inhibition, at one concentration (the size of the read-out at that concentration, not a potency): 82%
Estimate against measurement, compound 3: 2 percentage points below; measured number inside the range.
By their numbers in this assay, from the lowest: compounds 2, 3 and 1 (each within the scatter of the next).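

In this assay, methoxy in place of fluoro on the aromatic carbon para to a large group gives a number 1 percentage points higher from compound 2 to compound 3 (within the scatter), so this position accepts either group without a step beyond the scatter. The second comparison, with 2,4-dimethoxyphenyl in place of 3-methylphenyl on the ring nitrogen, gives a number 2 percentage points lower from compound 1 to compound 3 (within the scatter), which extends what the single earlier step showed: all three aryl groups shown read alike at this nitrogen. Nothing available explains why these groups read alike.

From the compounds shown here alone, it remains open whether an amine or a carboxylic acid at this position, or a longer chain in place of the methoxy, would also stay within the scatter. Going by these compounds, the shared core and the chain on the amide are the same in all three compounds, so their contribution also remains open.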